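Compound 3: ethoxy in place of methoxymethyl

A few compounds are considered here, and "the series" means these few. Any claim that something is new, unique, unknown or untested is made for them only; others in the source may bear on it.

Measured in a physicochemical assay for lipophilicity, read by HPLC, at pH 7.5; a higher number here means a more lipophilic compound, a lower number a more polar compound:
- Compound 1 `CC[C@@H](Nc1c(C#N)c(-c2ccc(-c3cnccc3C)cc2)nc2cnccc12)C(N)=O`: 2
- Compound 2 `CC[C@@H](Nc1c(C#N)c(-c2ccc(-c3ccccc3COC)cc2)nc2cnccc12)C(N)=O`: 2.6

Of these two, compound 2 stands higher at 2.6. Among the measured compounds shown here, the only measured step is a number 0.60 log units higher from compound 1 to compound 2 (beyond the scatter), where 2-(methoxymethyl)phenyl takes the place of 4-methylpyridin-3-yl on an aromatic carbon.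

The next compound to be read is compound 3 `CCOc1ccccc1-c1ccc(-c2nc3cnccc3c(N[C@H](CC)C(N)=O)c2C#N)cc1`. Its difference is ethoxy in place of methoxymethyl on an aromatic carbon. The two have the same atoms, joined differently: ethoxy in place of methoxymethyl on an aromatic carbon, and the same difference can be read as 2-(methoxymethyl)phenyl to 2-ethoxyphenyl.

For the measured compounds named here, no measured step exchanges these two groups. The step of a number 0.60 log units higher from compound 1 to compound 2 (beyond the scatter) bears on this only loosely, since it swaps a whole aromatic substituent and not just an isomeric side chain. A much smaller move is therefore expected here. The expected change is a number 0.20 log units higher from compound 2 to compound 3 (within the scatter), a slight rise that would probably stay within the scatter.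

For compound 3, the estimated value in this assay is 2.8, with an expected range from 2.4 to 3.2.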

Compound 3, distribution coefficient: 3
Compound 3: the middle estimate sits 0.20 log units below what was measured, and the stated range covers the measured number.
By their numbers in this assay, from the lowest: compound 1; then compound 2; then compound 3.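

In this assay, the exchange of methoxymethyl for ethoxy gives a number 0.40 log units higher from compound 2 to compound 3 (beyond the scatter), which is beyond the scatter, so at this place on an aromatic carbon, ortho to a large group, the reading depends on how the atoms are joined and not only on which atoms are present: the group that leaves and the group that enters have the same heavy atoms and the same counts of donors and acceptors. The new comparison with the pyridine-bearing compound gives a number 1.00 log units higher from compound 1 to compound 3 (beyond the scatter), a larger step than a number 0.60 log units higher from compound 1 to compound 2 (beyond the scatter), so the size of the move away from 4-methylpyridin-3-yl depends on which 2-substituted phenyl takes its place. No supporting measurement accounts for the difference between these two isomeric groups.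

The compounds shown leave open whether the reading tracks where the oxygen stands in the side chain, which a longer chain such as propoxy or an amine such as dimethylaminomethyl at the same place would help to test. They also leave open whether ethoxy in place of methoxymethyl gives a step of this size on a pyridine ring.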